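The compounds below may be only part of what the source reports. "The series", "measured", "known", "first", "only" and "open" are said of these compounds alone.

Compound 1 `Cc1cc(-c2nc3cc(F)ccc3o2)ccc1NC(=O)CCl` is the starting point here. In a functional assay on C6 cells (Rattus norvegicus) for cytotoxicity, read by MTT assay, with a stated time of 24 h (on this read-out higher numbers stand for weaker inhibition and lower numbers for stronger inhibition), compound 1 gives > 100000 nM, and this is a limit of the assay rather than a measured number. A second compound, compound 2 `Cc1cc(-c2nc3cc(F)ccc3o2)ccc1NC(=O)CN1CCN(CCN(C)C)CC1`, is also known; in this assay compound 2 gives 10700 nM. Compound 1 stands at the limit of > 100000 nM in this assay, at which 1 of the 2 values shown sits. Compound 3 `Cc1ccc2oc(-c3ccc(NC(=O)CCl)c(C)c3)nc2c1` differs from compound 1 by a single change: methyl in place of fluoro on an aromatic carbon. For the measured compounds named here, no measured pair shows what this swap does in this assay, so the expectation rests on compound 1 alone, whose value > 100000 nM is a limit. The step from compound 1 to compound 3 is expected to be a number no higher from compound 1 to compound 3 (the limit leaves the size open), none beyond the scatter. Compound 3 is therefore estimated at 100000 nM, with a range from 30000 nM to 300000 nM, and quite possibly only a limit will be reported again.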

Compound 3, half-maximal inhibitory concentration: 97600 nM
Compound 3: middle estimate off by 1.0-fold (0.01 log units), on the high side; the measured number falls inside the stated range.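

Compound 3 gives a measured number in this assay, 97600 nM, so with methyl on this aromatic carbon the read-out lands on a real value, which fluoro in compound 1 did not provide. Methyl in place of fluoro gives an at least 1.0-fold lower number from compound 1 to compound 3 (0.01 log units; that floor lies within the scatter), so this swap shows no change beyond the scatter, although only a floor on the step is known and the true step could be larger. The size of the step stays open because compound 1 sits at a limit and not at a number: the limit of > 100000 nM in this assay, at which 1 of the 3 values shown sits.

Going by these compounds, what other groups on this aromatic carbon, such as chloro, methoxy or an amine, would do to the number remains open. Also open, on these data alone, is whether methyl in place of fluoro would act the same way in compound 2, which carries a different chain on the amide.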